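A dimethylamino step from compound 2 to compound 4

The source may hold more compounds than are shown below. What is called first, only, known or untested is meant among the compounds shown, and "the series" means these compounds.

Measured so far in a functional assay, with a stated time of 10 min; a lower number here means a stronger inhibitor, a higher number a weaker inhibitor:
compound 1 `O=c1cc(/C=C/c2ccccc2)[nH]cc1O` gives 4030 nM
compound 2 `Cn1cc(O)c(=O)cc1/C=C/c1ccccc1` gives 2110 nM
compound 3 `Cn1cc(O)c(=O)cc1/C=C/c1cccc(F)c1` gives 1310 nM

Compound 2 (2110 nM) stands within the scatter of both other compounds, so the three numbers offer a narrow base for comparison. Compound 4 `CN(C)c1ccc(/C=C/c2cc(=O)c(O)cn2C)cc1` is not yet measured. It differs from compound 2 by dimethylamino in place of hydrogen on an aromatic carbon, para to a large group (dimethylamino in place of hydrogen on an aromatic carbon). The closest measured precedent is fluoro in place of hydrogen on an aromatic carbon, which gave a 1.6-fold lower number from compound 2 to compound 3 (0.21 log units; within the scatter) in this assay. Methyl in place of hydrogen on an aromatic nitrogen gave a 1.9-fold lower number from compound 1 to compound 2 (0.28 log units; within the scatter), but that change lies elsewhere and bears less directly. Among the compounds with values here, no measured compound carries dimethylamino, so the range must stay wide. The expected result is a 1.4-fold lower number from compound 2 to compound 4 (0.15 log units; within the scatter), with no step beyond the scatter anticipated. For compound 4 the estimated value is 1500 nM, with an expected range from 500 nM to 4500 nM in this assay.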

Compound 4, half-maximal inhibitory concentration: 2520 nM
Beside the measured number, compound 4's estimate is 1.7-fold (0.23 log units) below it; the range from low to high includes it.
By their numbers in this assay, from the lowest: compounds 3, 2, 4 and 1 (each within the scatter of the next, the first and the last beyond it).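

Dimethylamino on an aromatic carbon, para to a large group, gives a 1.2-fold higher number from compound 2 to compound 4 (0.08 log units; within the scatter) in this assay and so stays within the scatter. The earlier compounds shown here showed only fluoro on this six-membered aromatic ring of carbon only, with a 1.6-fold lower number from compound 2 to compound 3 (0.21 log units; within the scatter) in this assay, whereas this result shows that this position can carry a group of 3 heavy atoms with no step beyond the scatter. Nothing measured here accounts for this result.

The compounds shown leave open whether a carboxylic acid or a longer chain on this same carbon would bring a step beyond the scatter. They also leave open whether dimethylamino would give a similar number at another carbon of this ring.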